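Swapping the dichlorophenyl arm for a fluorophenyl arm

This account rests on a few compounds, and the source may have more. Where it says the series, first, only, none or still open, it means among the compounds named here.

This account follows one change made on compound 1, whose structure is `C=CCn1c(=O)/c(=C\c2ccc(Cl)c(Cl)c2)[nH]c(=O)/c1=C\c1ccccc1OC`. In a functional assay on NCI-H1975 cells (Homo sapiens) for cytotoxicity, read by CCK-8 assay, with a stated time of 72 h (a higher number here means a weaker inhibitor, a lower number a stronger inhibitor), compound 1 gives "not active" (no number reported), so no number stands for it; it is one of two entries without a single number. Compound 2, `C=CCn1c(=O)/c(=C\c2ccc(Cl)c(Cl)c2)[nH]c(=O)/c1=C\c1ccccc1`, likewise gives "not active" (no number reported) in this assay. Going by the values given here, the only numbered entry is compound 3, `COc1ccccc1/C=c1\c(=O)[nH]/c(=C/c2ccccc2Cl)c(=O)n1C`, which in this assay gives 200 nM. Among the compounds with values here, no step between any two measured compounds is recorded, so the values of compound 1 and compound 3 can only be set side by side: one reports no activity, the other a number.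

Compound 4, `C=CCn1c(=O)/c(=C\c2ccccc2F)[nH]c(=O)/c1=C\c1ccccc1OC`, has not been measured. It differs from compound 1 in one place: 2-fluorophenyl in place of 3,4-dichlorophenyl on a double-bonded chain carbon bound to an aromatic carbon. Compound 3 also carries an aryl group with a single halogen on the benzylidene arm and gives 200 nM, while compound 1 gives "not active" (no number reported), so a move toward a measurable number is expected in this assay, though its size cannot be read from a recorded step. For compound 4 an estimated value of 1500 nM is expected in this assay, within a range from 200 nM to 10000 nM.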

Compound 4, half-maximal inhibitory concentration: 25100 nM
Compound 4: the middle estimate sits 17-fold (1.22 log units) below what was measured, outside the stated range (above it).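

In this assay, going by these compounds alone, compound 4 gives 25100 nM while compound 1 gives "not active" (no number reported) and so has no single number, which means no step between the two can be read. The compounds shown leave open how far 2-fluorophenyl in place of 3,4-dichlorophenyl shifts the value. No evidence at hand bears on this result.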